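Side-Chain Variation Beneath a Cytotoxicity Ceiling

The compounds below may be only part of what the source reports. "The series", "measured", "known", "first", "only" and "open" are said of these compounds alone.

In an ADME assay on CRL8155 cells (Homo sapiens) for cytotoxicity, read by resazurin assay, with a stated time of 72 h (a higher number here means that more compound is needed for the effect, a lower number that less compound is needed), compound 1 `O=C(NCCCCO)Nc1nc2ccc(C(=O)c3ccccc3)cc2[nH]1` gives no number, only the limit of > 30000 nM. Compound 2 `CN1CCC(CCn2c(N)nc3ccc(C(=O)c4ccccc4)cc32)CC1` likewise stops at the limit of > 30000 nM. Compound 3 `CN1CCC[C@@H]1Cn1c(N)nc2ccc(C(=O)c3ccccc3)cc21` stands no differently in this assay, reaching only the limit of > 30000 nM. All three rest at the limit of > 30000 nM in this assay, at which 3 of the 3 values shown sit, which is why the step that the two limits leave unreadable from compound 2 to compound 3 cannot be read. Compound 4 `CC(C)(C)Cn1c(N)nc2ccc(C(=O)c3ccccc3)cc21` differs from compound 3 by tert-butyl in place of 1-methylpyrrolidin-2-yl on a saturated chain carbon bound to an aromatic nitrogen. Going by the values given here, no measured step bears on this change, since the one pair altered at the same place yields two limits. The analyst therefore expects no readable step, and the expected step of a number no higher from compound 3 to compound 4 (the limit leaves the size open) reflects that. Compound 4 is estimated at 30000 nM, within 12000 nM to 100000 nM, most likely again as a limit.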

Compound 4, half-maximal effective concentration: > 30000 nM
Compound 4 was reported as a limit (the forecaster's own chance of this, stated with the estimate: 85%); the middle value sits exactly at the limit.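

Compound 4 also gives only a limit, so no step from compound 2 or compound 3 to compound 4 can be read in this assay, because all the compounds rest at one value: the limit of > 30000 nM in this assay, at which 4 of the 4 values shown sit.

The compounds shown leave open how far apart these side chains truly lie.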